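This account rests on a few compounds, and the source may have more. Where it says the series, first, only, none or still open, it means among the compounds named here.

Within an assay on isolated protein for inhibition of sodium-dependent dopamine transporter (Homo sapiens), tested at 10 uM (on this read-out higher numbers stand for more inhibition at the one concentration tested (going by the name of the read-out) and lower numbers for less inhibition), the three measured compounds span a wide range. Compound 1, `CO[C@@H]1CN(CC2Cc3ccccc3C2)CC[C@H]1n1c(C)nc2cc(C)ccc21`, gives 8%. Compound 2, `CO[C@H]1CN(CCCc2cccc(NC(=O)C3CC3)c2)CC[C@@H]1n1c(C)nc2cc(C)ccc21`, gives 32%. Compound 3, `COC(=O)Nc1ccc2c(c1)C[C@@H](CN1CC[C@@H](n3c(C)nc4cc(C)ccc43)[C@H](OC)C1)C2`, gives 65% and so stands highest of the three, with the gap to compound 2 and the gap to compound 1 both beyond the scatter.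

Among the measured compounds shown here, the one step between compounds differing in a single place is the one in which (methoxycarbonyl)amino replaces hydrogen on an aromatic carbon: a number 57 percentage points higher from compound 1 to compound 3 (beyond the scatter). That step bears directly on the move to compound 4, `CO[C@@H]1CN(C[C@H]2Cc3ccc(Br)cc3C2)CC[C@H]1n1c(C)nc2cc(C)ccc21`, which differs from compound 3 as follows: bromo in place of (methoxycarbonyl)amino on an aromatic carbon. The change removes the very group whose entry carried compound 1 up to compound 3, and puts a bromo in its place, a group with no hydrogen-bond donor and no acceptor, as counted. For the measured compounds named here, no measured step shows what bromo alone does at this position, so the expectation rests on the loss of the (methoxycarbonyl)amino group: compound 4 is expected to fall back a good part of the way toward compound 1, with a step of a number 40 percentage points lower from compound 3 to compound 4 (beyond the scatter). The estimate for compound 4 in this assay is therefore 25%, within a range from 5% to 55%.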

Compound 4, a percentage reported as inhibition, at one concentration (the size of the read-out at that concentration, not a potency): 80%
Estimate against measurement, compound 4: 55 percentage points below, outside the stated range (above it).
By their numbers in this assay, from the lowest: compound 1; then compound 2; then compound 3; then compound 4.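

In this assay, the step that exchanges the group, a number 15 percentage points higher from compound 3 to compound 4 (beyond the scatter), shows that (methoxycarbonyl)amino is not required on this aromatic carbon, since bromo, which has 0 hydrogen-bond donors and 0 hydrogen-bond acceptors, gives a higher number in its place. Set beside the earlier step, a number 57 percentage points higher from compound 1 to compound 3 (beyond the scatter), the new step from hydrogen to bromo, a number 72 percentage points higher from compound 1 to compound 4 (beyond the scatter), shows that two very different groups both lift the number well above that of the unsubstituted compound, so the earlier rise cannot be read as specific to (methoxycarbonyl)amino. Nothing available here accounts for either rise or for the order of the two groups.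

As far as these compounds go, with only hydrogen, (methoxycarbonyl)amino and bromo compared at this place, it remains open whether chloro, a primary amine or a carboxylic acid there would keep the number as high as bromo does. Each number in this assay is also a single reading at one concentration, so the compounds shown leave open how far the gain from bromo would carry over into a measured potency.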